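Phenyl for methyl on the piperidine-type ring: inhibition outlook

The source may report more compounds than this note shows. Statements on the series, on what has been measured and on what is new or still open speak of the compounds shown alone.

Measured so far:
compound 1, `c1ccc(-c2nc(N3CCC(c4ccccc4)CC3)c3ccccc3n2)cc1`: 85.3%
compound 2, `CC1CCN(c2nc(-c3ccc(Cl)cc3)nc3ccccc23)CC1`: 55.1%

In a functional assay on the whole organism for inhibition, with Rattus norvegicus as the target, read by paw edema, with stated times of 4 days, 1 h and 2 h, at a dose of 100 mg/kg by the oral route (a lower number here means less inhibition, a higher number more inhibition at the dose given (going by the name of the read-out)), compound 1 gives 85.3%. In this assay compound 2 gives 55.1%, the lowest of the two numbers recorded; its nearest neighbour is compound 1, whose number lies higher by a gap beyond the scatter.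

The next compound, compound 3, `Clc1ccc(-c2nc(N3CCC(c4ccccc4)CC3)c3ccccc3n2)cc1`, has not yet been measured. Compared with compound 2 the change is phenyl in place of methyl on a saturated ring carbon. Within the data shown here, no step between two measured compounds is available for this exact change, so the expectation rests on the two values alone.

Given that compound 1, which carries phenyl on the saturated ring carbon, reaches 85.3%, the phenyl-bearing compound 3 is expected to move up from compound 2 by a step of a number 19.9 percentage points higher from compound 2 to compound 3 (beyond the scatter), a rise beyond the scatter. Compound 3 is therefore estimated at 75%, with a plausible range from 55% to 92%.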

Compound 3, a percentage reported as inhibition, in the whole organism at one dose (the size of the read-out at that dose, not a potency): 53.7%
Compound 3: middle estimate off by 21.3 percentage points, on the high side; the measured number lies below the stated range.
By their numbers in this assay, from the lowest: compounds 3 and 2 (each within the scatter of the next); then compound 1.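

In this assay, phenyl in place of methyl on a saturated ring carbon gives a number 1.4 percentage points lower from compound 2 to compound 3 (within the scatter), so with the chloro group present, the read-out does not separate these two groups at this position. With phenyl held on that ring carbon, chloro in place of hydrogen on an aromatic carbon gives a number 31.6 percentage points lower from compound 1 to compound 3 (beyond the scatter), so phenyl alone does not carry the high number of compound 1, and the chloro change counts for far more in this pair than the phenyl change does in the other. Nothing available explains either step.

Going by these compounds, whether phenyl and methyl also stand level on the core without the chloro group remains open, as does whether an amine or a carboxylic acid on the saturated ring carbon, or methoxy in place of chloro on the aromatic carbon, would shift the number in this assay. Each number is also a read-out at one dose, so the compounds shown leave open how their potencies compare.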